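Removing one chlorine from a dichlorinated purine analogue

The source may hold more compounds than are shown below. What is called first, only, known or untested is meant among the compounds shown, and "the series" means these compounds.

For the measured compounds named here, compound 2 `ClCc1ccccc1Cn1cnc2c(Cl)nc(Cl)nc21` gives 1310 nM in a functional assay on UACC-62 cells (Homo sapiens) for cytotoxicity, read by sulforhodamine B assay, with a stated time of 48 h (a lower number here means a stronger inhibitor of growth, a higher number a weaker inhibitor of growth), the highest of the two numbers so far; the nearest is compound 1 `ClCc1ccc(Cn2cnc3c(Cl)ncnc32)cc1`, which in this assay gives 1230 nM, a gap that lies within the usual scatter. Compound 3 `ClCc1ccccc1Cn1cnc2c(Cl)ncnc21` differs from compound 2 in one place: hydrogen in place of chloro on an aromatic carbon, on an aromatic carbon of a six-membered aromatic ring with two nitrogens, between two ring nitrogen atoms, meta to a chloro group. Going by the values given here, no step between two measured compounds isolates this change, and the two measured values sit close together, so no movement beyond the scatter in either direction is anticipated. Compound 3 is therefore expected to give about 1200 nM in this assay, within a range from 500 nM to 3000 nM. The estimated step of a 1.1-fold lower number from compound 2 to compound 3 (0.04 log units; within the scatter) is thus expected to stay within the scatter.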

Compound 3, concentration for 50% growth inhibition: 3310 nM
Compound 3: the middle estimate sits 2.8-fold (0.44 log units) below what was measured; measured number outside the range, above it.
By their numbers in this assay, from the lowest: compounds 1 and 2 (each within the scatter of the next); then compound 3.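

In this assay, for the compounds shown here, the chloro group on the aromatic carbon between two ring nitrogen atoms proves to matter: hydrogen in its place gives a 2.5-fold higher number from compound 2 to compound 3 (0.40 log units; beyond the scatter), a modest step and the first single-place change that can be read in this set. Compound 3 still inhibits growth without this chloro group, so the position affects the size of the number without growth inhibition being lost. No measurement at hand explains the step.

The compounds shown leave open whether another group at this position, such as an amine, a methoxy group or a nitrile, would match compound 2 or move further from it. They also leave open whether the same change would give a step of similar size with the chloromethyl group placed as in compound 1.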